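Fluoro for Bromo: Little Change Expected

This account rests on a few compounds, and the source may have more. Where it says the series, first, only, none or still open, it means among the compounds named here.

Of the compounds shown here, three of the shared core have been measured in a functional assay on MCF7 cells (Homo sapiens) for inhibition; a higher number here means a weaker inhibitor, a lower number a stronger inhibitor. Compound 1 `O=C(/C=C/c1ccc(I)cc1)c1ccc(OCB(O)O)cc1` gives 9500 nM, compound 2 `O=C(/C=C/c1ccc(F)c(Br)c1)c1ccc(B(O)O)cc1` gives 8500 nM, and compound 3 `O=C(/C=C/c1ccc(I)cc1)c1ccc(O)cc1` gives 7000 nM. Compound 2 thus stands second highest of the three numbers, yet its gap to compound 1 and its gap to compound 3 both lie within the scatter, so the three cannot be told apart on these figures. Among the measured compounds shown here, the one measured step, a 1.4-fold lower number from compound 1 to compound 3 (0.13 log units; within the scatter), also lies within the scatter.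

Compound 4 `O=C(/C=C/c1ccc(F)c(F)c1)c1ccc(B(O)O)cc1` has not yet been measured. It differs from compound 2 in a single place: fluoro in place of bromo on an aromatic carbon. For the measured compounds named here, no measured pair shows this change; the only measured step concerns a group on an oxygen on an aromatic ring elsewhere on the core, and it was small. There is therefore no direct precedent for a fluoro in place of bromo at this place, and the absence of any step beyond the scatter among the three measured compounds gives no reason to expect one now.

In this assay compound 4 is expected to show a step of no change at the digits printed from compound 2 to compound 4 (within the scatter), within the scatter. The estimate for compound 4 in this assay is 8500 nM, with a range from 3000 nM to 25000 nM.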

Compound 4, half-maximal inhibitory concentration: 7800 nM
Estimate against measurement, compound 4: 1.1-fold (0.04 log units) above; the range from low to high includes it.
By their numbers in this assay, from the lowest: compounds 3, 4, 2 and 1 (each within the scatter of the next).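

At this place, on an aromatic carbon ortho to a fluoro group and meta to a large group, the exchange now has a measured pair of its own: fluoro in place of bromo gives a 1.1-fold lower number from compound 2 to compound 4 (0.04 log units; within the scatter) in this assay, and this is the only direct reading of the change among the compounds shown. The earlier step concerned a group on an oxygen on an aromatic ring, so it said nothing about this place, whereas this pair shows that bromo and fluoro here cannot be told apart on these figures. No measurement is at hand that would account for this result.

What the compounds shown leave open is whether this place responds at all, since only two halogens are compared here and a single pair within the scatter cannot show that other groups would behave alike. An amine, a carboxylic acid or a longer chain such as an ethoxy group on this aromatic carbon would test whether any change here moves the number beyond the scatter.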